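One halogenated ring for another: compound 2 to compound 3

The source may report more compounds than this note shows. Statements on the series, on what has been measured and on what is new or still open speak of the compounds shown alone.

Measured so far:
compound 1 `O=C(CSc1nc(Nc2ccccc2)c2ccccc2n1)Nc1cccc([N+](=O)[O-])c1` — 28100 nM
compound 2 `C=CC(=O)Nc1cccc(NC(=O)CSc2nc(Nc3ccccc3F)c3ccccc3n2)c1` — 26100 nM

Of the compounds shown here, two have been measured in a functional assay on MGC-803 cells (Homo sapiens) for inhibition, read by MTT assay, with a stated time of 72 h; on this read-out lower numbers stand for stronger inhibition and higher numbers for weaker inhibition. Compound 1 gives 28100 nM in this assay, and compound 2 gives 26100 nM. Compound 2 holds the lowest of the two numbers, but its nearest neighbour, compound 1, sits within the scatter of it, so the two values cannot be told apart; both point to weak inhibition.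

Compound 3 `C=CC(=O)Nc1cccc(NC(=O)CSc2nc(Nc3ccc(Cl)cc3)c3ccccc3n2)c1` differs from compound 2 in one place: 4-chlorophenyl in place of 2-fluorophenyl on a nitrogen on an aromatic ring. Going by the values given here, no measured pair shows this change, so there is no step to lean on. Among the compounds with values here, the only guide is that compounds 1 and 2, which carry different rings on that nitrogen among other differences, give values that sit close together. On that basis the step from compound 2 to compound 3 is expected to be small, a 1.2-fold lower number from compound 2 to compound 3 (0.07 log units; within the scatter), with no direction that can be argued from the data. Compound 3 is therefore expected to give about 22000 nM in this assay, in a range of 7000 nM to 60000 nM.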

Compound 3, half-maximal inhibitory concentration: 14300 nM
Estimate against measurement, compound 3: 1.5-fold (0.19 log units) above; the range from low to high includes it.
By their numbers in this assay, from the lowest: compounds 3, 2 and 1 (each within the scatter of the next).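

In this assay, going by these compounds alone, this is the first comparison that changes only the ring on this nitrogen while keeping the rest of the molecule the same. Replacing 2-fluorophenyl with 4-chlorophenyl gives a 1.8-fold lower number from compound 2 to compound 3 (0.26 log units; within the scatter), so this pair cannot be told apart, even though the step changes both the halogen and its place on the ring. At this level of inhibition, the position therefore accepts this particular exchange of one halogenated phenyl ring for another without a change that stands clear of the scatter, and nothing measured here bears on the size of the step.

Still open, from the compounds shown here alone, is whether the kind of halogen and its place on the ring would each have an effect if changed alone, since this single step alters both together. Also open, going by these compounds, is what would happen on this nitrogen with a phenyl ring carrying an amine or a carboxylic acid, or with a longer carbon chain in place of the ring.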